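Moving the fluorine on the ring attached to the aromatic nitrogen

The source may hold more compounds than are shown below. What is called first, only, known or untested is meant among the compounds shown, and "the series" means these compounds.

Measured compounds:
- compound 1, `CNC(=O)c1cc(Oc2ccc(NC(=O)c3nn(-c4cccc(F)c4)c(=O)cc3C)cc2F)ccn1`: 6410 nM
- compound 2, `Cc1cc(=O)n(-c2ccccc2OC(F)(F)F)nc1C(=O)Nc1ccc(Oc2ncnc3ccsc23)cc1`: 23800 nM
- compound 3, `Cc1cc(=O)n(-c2cccc(F)c2)nc1C(=O)Nc1ccc(Oc2ncnc3ccsc23)cc1`: 6410 nM

All three compounds were tested in a functional assay on MCF7 cells (Homo sapiens) for cytotoxicity, read by MTT assay, with a stated time of 72 h; a lower number here means a stronger inhibitor, a higher number a weaker inhibitor. Compound 3 stands level with compound 1 at the digits shown, the two together giving the lowest numbers of the three, and the gap between them lies within the usual scatter. Among the compounds with values here, compound 2 sits furthest from compound 3, and the only single-change step among the measured compounds runs between them: a 3.7-fold lower number from compound 2 to compound 3 (0.57 log units; beyond the scatter), a modest change in the direction of stronger inhibition.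

Compound 4, `Cc1cc(=O)n(-c2ccc(F)cc2)nc1C(=O)Nc1ccc(Oc2ncnc3ccsc23)cc1`, has not yet been measured. It differs from compound 3 in one place: 4-fluorophenyl in place of 3-fluorophenyl on an aromatic nitrogen. The two compounds share every atom and differ only in where the fluorine sits on that ring.

Within the data shown here, no measured step tells how moving a fluorine on this ring affects the number. Among the measured compounds shown here, the one step that does exist, from compound 2 to compound 3, concerns a different substituent altogether, so it offers little guidance here. The step of a 1.0-fold higher number from compound 3 to compound 4 (0.01 log units; within the scatter) is therefore expected to stay within the scatter, in no clear direction. Compound 4 is estimated at 6500 nM, with a range from 2500 nM to 17000 nM.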

Compound 4, half-maximal inhibitory concentration: 4400 nM
Beside the measured number, compound 4's estimate is 1.5-fold (0.17 log units) above it; the range from low to high includes it.
By their numbers in this assay, from the lowest: compounds 4, 1 and 3 (each within the scatter of the next); then compound 2.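

In this assay, within the data shown here, the change from 3-fluorophenyl to 4-fluorophenyl on the aromatic nitrogen gives a 1.5-fold lower number from compound 3 to compound 4 (0.16 log units; within the scatter) and offers the first direct look at where a fluorine sits on this ring; in this one pair, the move produces no difference that can be told apart from ordinary assay variation. Replacing 2-(trifluoromethoxy)phenyl with 4-fluorophenyl gives a 5.4-fold lower number from compound 2 to compound 4 (0.73 log units; beyond the scatter) and, alongside a 3.7-fold lower number from compound 2 to compound 3 (0.57 log units; beyond the scatter) as the earlier step, shows that compound 2 stands apart from both fluorophenyl compounds by more than the scatter, whichever of the two fluorine placements is present. Nothing available here accounts for either result.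

The compounds shown leave open how this ring would respond to a different kind of group in the same place, such as an amine, a carboxylic acid or a methoxy group. They also do not show whether 4-fluorophenyl and 3-fluorophenyl would remain this close on the core of compound 1, where only 3-fluorophenyl appears.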